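Hydroxyacyl amide variation on the shared core

A few compounds are considered here, and "the series" means these few. Any claim that something is new, unique, unknown or untested is made for them only; others in the source may bear on it.

Compound 2 `CC1(C)Cc2c(sc(NC(=O)c3cccnc3O)c2C(N)=O)C(C)(C)O1` carries the shared core of compound 1 `CC1(C)Cc2c(sc(NC(=O)c3ccccc3O)c2C(N)=O)C(C)(C)O1` with a 2-hydroxypyridin-3-yl in place of the 2-hydroxyphenyl. Within the data shown here, in an assay on cells for positive allosteric modulation of Cystic fibrosis transmembrane conductance regulator variant F508del (Homo sapiens), with stated times of 10 min and 7 s, in the presence of a further agent that is not named here (a higher number here means that more compound is needed for the effect, a lower number that less compound is needed), compound 1 gives 4 nM, and compound 2 gives 190 nM, the higher of the two numbers known so far; the only neighbour is compound 1, reached by a 48-fold higher number from compound 1 to compound 2 (1.68 log units; beyond the scatter).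

Compound 3 `CC1(C)Cc2c(sc(NC(=O)C3(CO)CC3)c2C(N)=O)C(C)(C)O1` is not yet measured. Relative to compound 2 the change is 1-(hydroxymethyl)cyclopropyl in place of 2-hydroxypyridin-3-yl on a carbonyl carbon. Among the measured compounds shown here, the one measured step, a 48-fold higher number from compound 1 to compound 2 (1.68 log units; beyond the scatter), concerns a change within an aromatic ring and does not directly cover the move to a non-aromatic ring; it only shows that the acyl group is sensitive to change, and that a hydroxy-bearing six-membered aromatic ring is common to both measured compounds. For the measured compounds named here, no measured pair informs the size of the present step with confidence.

A modest further rise in the number is therefore expected for compound 3, with a wide range, a 3.2-fold higher number from compound 2 to compound 3 (0.50 log units; beyond the scatter). The estimate for compound 3 is 600 nM, between 100 nM and 4000 nM.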

Compound 3, half-maximal effective concentration: 15 nM
The estimate for compound 3 lay 40-fold (1.60 log units) above the measured number, outside the stated range (below it).
By their numbers in this assay, from the lowest: compound 1; then compound 3; then compound 2.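

In this assay, the acyl group on the carbonyl carbon does not need an aromatic ring for a low number: 1-(hydroxymethyl)cyclopropyl in place of 2-hydroxypyridin-3-yl gives a 13-fold lower number from compound 2 to compound 3 (1.10 log units; beyond the scatter), a large step in the opposite direction to the one seen on moving from 2-hydroxyphenyl to 2-hydroxypyridin-3-yl. The three-membered non-aromatic ring of carbon only does not fully match the 2-hydroxyphenyl, however, with a 3.8-fold higher number from compound 1 to compound 3 (0.57 log units; beyond the scatter), a modest step that leaves compound 1 with the lowest number of the three and places compound 3 between the two aromatic examples. Nothing available explains either step or the reversal in order between the aromatic and non-aromatic groups.

All three acyl groups shown carry a hydroxy group, which leaves open how an amine or a carboxylic acid in its place would read in this assay, and how a simple methyl on the cyclopropane would compare. Also open, going by these compounds, is whether the low number of compound 3 is tied to the three-membered ring, or would persist with a cyclobutane, a longer hydroxyethyl chain or an open-chain hydroxyalkyl group.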